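Cytotoxicity limits in an oxazolidinone series

The source may hold more compounds than are shown below. What is called first, only, known or untested is meant among the compounds shown, and "the series" means these compounds.

Measured compounds in an ADME assay on L02 cells (Homo sapiens) for cytotoxicity, read by MTT assay, with a stated time of 48 h; a lower number here means a stronger inhibitor, a higher number a weaker inhibitor:
compound 1 `O=C1O[C@@H](CN2CCCCC2)CN1c1ccc(-n2cc(-c3ccccn3)cn2)c(F)c1`: > 400 ug/mL
compound 2 `COC(=O)CC1CCN(C[C@H]2CN(c3ccc(-n4cc(-c5ccccn5)cn4)c(F)c3)C(=O)O2)CC1`: > 400 ug/mL
compound 3 `O=C1O[C@@H](CNC(=O)C(F)(F)F)CN1c1ccc(-n2cc(-c3ccccn3)cn2)c(F)c1`: > 400 ug/mL

Each of the three values is a limit of the assay, not a number. Compound 1 therefore cannot be placed within the set: compound 2 and compound 3 sit at the same limit, so no order is visible among them, and the limit of > 400 ug/mL in this assay, at which 3 of the 3 values shown sit, describes the whole set. The steps a step that the two limits leave unreadable from compound 1 to compound 2, a step that the two limits leave unreadable from compound 1 to compound 3 and a step that the two limits leave unreadable from compound 2 to compound 3 are all unreadable for the same reason.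

Compound 4 `CONC(=O)[C@H]1CN(c2ccc(-n3cc(-c4ccccn4)cn3)c(F)c2)C(=O)O1` differs from compound 1 by methoxycarbamoyl in place of (piperidin-1-yl)methyl on a saturated ring carbon. The step from compound 1 to compound 3 concerns the same side of the core, but it gives no readable size, so the expectation for compound 4 rests only on the fact that every measured compound sits at the limit. Compound 4 is expected to show a number no higher from compound 1 to compound 4 (the limit leaves the size open), that is, no readable step in this assay. For compound 4 the estimate in this assay is 400 ug/mL, with a range from 200 ug/mL to 800 ug/mL, most likely again reported only as a limit.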

Compound 4, half-maximal inhibitory concentration: > 400 ug/mL
Compound 4 ended at the assay's limit (the forecaster's own chance of this, stated with the estimate: 85%); the middle value lies on the limit itself.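

No step between compound 4 and compound 1, compound 2 or compound 3 can be read in this assay, since all four compounds share one limit: the limit of > 400 ug/mL in this assay, at which 4 of the 4 values shown sit.

The compounds shown leave open at what concentration any of them becomes cytotoxic, and whether any replacement on the saturated ring carbon changes that concentration.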